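Replacing 4-nitrophenyl with 2-fluorophenyl

The source may report more compounds than this note shows. Statements on the series, on what has been measured and on what is new or still open speak of the compounds shown alone.

Compound 1 `CC(C)[C@H](NC(=O)COc1cccc2ccccc12)C(=O)N[C@@H](CC(=O)O)C(=O)COc1ccccc1`: 14000 nM
Compound 2 `CC(C)[C@H](NC(=O)COc1cccc2ccccc12)C(=O)N[C@@H](CC(=O)O)C(=O)COc1ccc([N+](=O)[O-])cc1`: > 100000 nM

These values come from a functional assay on Jurkat cells (Homo sapiens); a lower number here means a stronger inhibitor, a higher number a weaker inhibitor. Compound 2 gives > 100000 nM, which is a limit of the assay and not a number. Compound 3 `CC(C)[C@H](NC(=O)COc1cccc2ccccc12)C(=O)N[C@@H](CC(=O)O)C(=O)COc1ccccc1F` changes the group on the oxygen: 2-fluorophenyl in place of 4-nitrophenyl on an oxygen on a saturated carbon. In words, 2-fluorophenyl stands in place of 4-nitrophenyl on an oxygen on a saturated carbon.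

For the measured compounds named here, only one measured step bears on this change: an at least 7.1-fold higher number from compound 1 to compound 2 (0.85 log units; beyond the scatter), with nitro in place of hydrogen on an aromatic carbon. Compound 3 has no nitro group, so most of that loss is expected to be recovered. Going by the values given here, no measured step shows what the 2-fluorophenyl group does by itself, which keeps the range wide. The expected change is an at least 10-fold lower number from compound 2 to compound 3 (1.00 log units; beyond the scatter), towards a lower number. For compound 3 the estimate is 10000 nM, with an expected range of 2000 nM to 50000 nM.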

Compound 3, half-maximal inhibitory concentration: > 100000 nM
Compound 3 ended at the assay's limit (the forecaster's own chance of this, stated with the estimate: 10%); middle value at least 10-fold (1.00 log units) away from the limit.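

Putting a fluoro group on the phenyl ring of compound 1 gives an at least 7.1-fold higher number from compound 1 to compound 3 (0.85 log units; beyond the scatter) in this assay, so the nitro group of compound 2 is not the only substituent here that goes with a weaker result. Compound 3 gives > 100000 nM, which is a limit of the assay and not a number. The step from compound 2 to compound 3 cannot be read, and neither compound can be ranked against the other, because both rest on the same limit: the limit of > 100000 nM in this assay, at which 2 of the 3 values shown sit.

Going by these compounds, how far beyond that limit either compound lies remains open. So does whether any group on this phenyl ring weakens the result, or only these two: a chlorine or a methoxy group there, or an amine in place of the fluoro group, could answer that.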